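Thiazole attachment point on the cyclopropane: estimating compound 4

The source may report more compounds than this note shows. Statements on the series, on what has been measured and on what is new or still open speak of the compounds shown alone.

Compound 3 `CC[C@H](C)[C@H](N)CN(C(=O)[C@@H]1C[C@H]1c1ncc(C)s1)c1ccc(-c2ccccc2)cc1` stands at 1300 nM in a functional assay for agonist activity at G protein-coupled receptor 88 (Homo sapiens), read by HTRF and cAMP accumulation (on this read-out higher numbers stand for an effect only at larger amounts of compound and lower numbers for an effect already at smaller amounts), level with compound 2 `CC[C@H](C)[C@H](N)CN(C(=O)[C@@H]1C[C@H]1c1ccc(F)cc1F)c1ccc(-c2ccccc2)cc1`, which gives 1300 nM in this assay; the step of no change at the digits printed from compound 2 to compound 3 (within the scatter) lies within the scatter. Compound 1 `CC[C@H](C)[C@H](N)CN(C(=O)[C@@H]1C[C@H]1c1ccc(OC)cc1)c1ccc(-c2ccccc2)cc1` reaches only a limit of the assay, > 25000 nM. The steps of an at least 19-fold lower number from compound 1 to compound 2 (1.28 log units; beyond the scatter) and an at least 19-fold lower number from compound 1 to compound 3 (1.28 log units; beyond the scatter) are both large, and both start from that limit (the limit of > 25000 nM in this assay, at which 1 of the 3 values shown sits).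

Compound 4 `CC[C@H](C)[C@H](N)CN(C(=O)[C@@H]1C[C@H]1c1csc(C)n1)c1ccc(-c2ccccc2)cc1` has not yet been measured. It differs from compound 3 by 2-methyl-1,3-thiazol-4-yl in place of 5-methyl-1,3-thiazol-2-yl on a saturated ring carbon. Going by the values given here, no measured pair shows this exact change. The measured steps on this carbon show that replacing 4-methoxyphenyl with either 2,4-difluorophenyl or 5-methyl-1,3-thiazol-2-yl lowers the number greatly, while the difluorophenyl and the thiazole themselves sit level with each other in no change at the digits printed from compound 2 to compound 3 (within the scatter). In compound 4 a thiazole with a methyl is kept; only the point of attachment and the place of the methyl move. The step is therefore expected to be small, a 1.4-fold higher number from compound 3 to compound 4 (0.14 log units; within the scatter), with no clear direction beyond the scatter. Compound 4 is estimated at 1800 nM in this assay, with a range from 600 nM to 6000 nM.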

Compound 4, half-maximal effective concentration: 1500 nM
Compound 4: the middle estimate sits 1.2-fold (0.08 log units) above what was measured; the measured number falls inside the stated range.
By their numbers in this assay, from the lowest: compounds 2, 3 and 4 (each within the scatter of the next). At a limit, above all of these: compound 1.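

In this assay, going by these compounds alone, the thiazole can change both its point of attachment to this saturated ring carbon and the place of its methyl without any change that stands out, since a 1.2-fold higher number from compound 3 to compound 4 (0.06 log units; within the scatter) is a step the earlier compounds could not show. The comparison with the fluorinated aryl group gives the same reading, a 1.2-fold higher number from compound 2 to compound 4 (0.06 log units; within the scatter), so 2,4-difluorophenyl, 5-methyl-1,3-thiazol-2-yl and 2-methyl-1,3-thiazol-4-yl cannot be told apart at this position on these numbers. Replacing 4-methoxyphenyl now gives a large step with a third group, an at least 16-fold lower number from compound 1 to compound 4 (1.22 log units; beyond the scatter), but this step gives only a bound and not an exact size, as it starts from a limit: the limit of > 25000 nM in this assay, at which 1 of the 4 values shown sits.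

The compounds shown leave open whether the methyl matters at all, as both thiazoles carry one, and an unsubstituted 1,3-thiazol-4-yl or a 2-ethyl-1,3-thiazol-4-yl would speak to that. They also leave open whether the methoxy group or the phenyl ring lies behind the limit seen with compound 1, a question that an unsubstituted phenyl or a 4-fluorophenyl on the same carbon would address.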